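Swapping a hydroxymethylphenyl for an isopropylphenyl on a shared core

The source may report more compounds than this note shows. Statements on the series, on what has been measured and on what is new or still open speak of the compounds shown alone.

The three measured compounds share one core. Compound 1, `CC[C@@H](Nc1c(C#N)c(-c2ccc(-c3cccc(CO)c3)cc2)nc2cnccc12)C(N)=O`, gives 2 in a physicochemical assay for lipophilicity, read by HPLC, at pH 7.5 (a lower number here means a more polar compound, a higher number a more lipophilic compound), the lowest of the three numbers, though its gaps to compound 2, `CC(C)(CC(N)=O)c1c(C#N)c(-c2ccc(Br)cc2)nc2cnccc12`, at 2.1, and to compound 3, `CC(Nc1c(C#N)c(-c2ccc(Br)cc2)nc2cnccc12)C(N)=O`, at 2.1, both lie within the scatter. For the measured compounds named here, the one measured step that changes a single place, no change at the digits printed from compound 2 to compound 3 (within the scatter), concerns a substituent on the core and not the aryl group, so it does not bear on the change followed here.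

Compound 4, `CC[C@@H](Nc1c(C#N)c(-c2ccc(-c3ccccc3C(C)C)cc2)nc2cnccc12)C(N)=O`, differs from compound 1 in one place: 2-isopropylphenyl in place of 3-(hydroxymethyl)phenyl on an aromatic carbon. The group that leaves carries one hydrogen-bond donor and one acceptor; the group that enters carries none, and consists of carbon only. Going by the values given here, no measured step covers such an exchange, so the expectation rests on the counted change alone. Compound 4 is therefore expected to be clearly more lipophilic, a step of a number 1.70 log units higher from compound 1 to compound 4 (beyond the scatter) well beyond the scatter. The estimate for compound 4 is 3.7, in a range from 2.9 to 4.5.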

Compound 4, distribution coefficient: 3.5
The estimate for compound 4 lay 0.20 log units above the measured number, within the range that was stated.
By their numbers in this assay, from the lowest: compounds 1, 2 and 3 (each within the scatter of the next); then compound 4.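

At this aromatic carbon, para to a large group, 2-isopropylphenyl in place of 3-(hydroxymethyl)phenyl gives in this assay a number 1.50 log units higher from compound 1 to compound 4 (beyond the scatter) as a large step on the shared core. For the compounds shown here, the earlier compounds offered no step at this place, so this is the first sign that the group held here can move the number beyond the scatter. No measurement at hand accounts for the size of this step.

The exchange alters both the substituent and its place in the group's name, 3-(hydroxymethyl) against 2-isopropyl, and the compounds shown do not separate how much of the step belongs to each. Where an unsubstituted phenyl, or a phenyl carrying an amine or a carboxylic acid, would fall at this carbon also stays open.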